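Butyl in Place of Cyclohexyl on the Amine Nitrogen

The compounds below may be only part of what the source reports. "The series", "measured", "known", "first", "only" and "open" are said of these compounds alone.

Compound 2 `COc1cc(/C=C/C(=O)/C=C(/C=C/c2ccc(O)c(OC)c2)NC2CCCCC2)ccc1O` gives 191% in a functional assay on EA.hy 926 cells (Homo sapiens), read by fluorescence, tested at 10 uM (on this read-out higher numbers stand for a stronger effect at the one concentration tested and lower numbers for a weaker effect), and compound 1 `CCC(C)NC(=C\C(=O)/C=C/c1ccc(O)c(OC)c1)/C=C/c1ccc(O)c(OC)c1` gives 184%, a gap that lies within the scatter. Among the compounds with values here, the single comparable step, a number 7 percentage points higher from compound 1 to compound 2 (within the scatter), also swapped the group on the amine nitrogen and moved the read-out only within the scatter. Compound 3 `CCCCNC(=C\C(=O)/C=C/c1ccc(O)c(OC)c1)/C=C/c1ccc(O)c(OC)c1` differs from compound 2 by butyl in place of cyclohexyl on an amine nitrogen. Because a number 7 percentage points higher from compound 1 to compound 2 (within the scatter) stayed within the scatter, no step beyond the scatter is expected here, and a number 6 percentage points lower from compound 2 to compound 3 (within the scatter) is estimated accordingly. Compound 3 is therefore expected to give 185%, within a range of 160% to 210%.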

Compound 3, a percentage reported as activity, at one concentration (the size of the read-out at that concentration, not a potency): 439%
The estimate for compound 3 lay 254 percentage points below the measured number; measured number outside the range, above it.
By their numbers in this assay, from the lowest: compounds 1 and 2 (each within the scatter of the next); then compound 3.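

In this assay the group on the amine nitrogen matters far more than the earlier pair suggested: butyl stands well clear of both cyclohexyl (a number 248 percentage points higher from compound 2 to compound 3 (beyond the scatter)) and sec-butyl (a number 255 percentage points higher from compound 1 to compound 3 (beyond the scatter)). Compound 1 also has no ring on this nitrogen yet stays within the scatter of compound 2, so the absence of a ring alone does not go with the higher number. Nothing measured here speaks to what lies behind the jump.

Still open, on these data alone, is whether a longer chain such as hexyl, a shorter one such as propyl, or a chain ending in a hydroxyl group would keep this high read-out.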